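Sulfur-bearing side chain on a smaller quinone core

This account rests on a few compounds, and the source may have more. Where it says the series, first, only, none or still open, it means among the compounds named here.

Measured compounds:
compound 1 `CSCC[C@H](NC1=CC(=O)C=C(C[C@]2(C)[C@@H](C)CC[C@]3(C)C(C)=CCC[C@@H]23)C1=O)C(=O)O`, 19400 nM
compound 2 `CC1=CCC[C@H]2[C@](C)(CC3=CC(=O)C=C(N[C@@H](C)C(=O)O)C3=O)[C@@H](C)CC[C@]12C`, 10300 nM
compound 3 `C[C@H](NC1=CC(=O)C=C(C(C)(C)C)C1=O)C(=O)O`, 20100 nM

In a functional assay on Fem-X cells (Homo sapiens) for cytotoxicity, read by MTT assay, with a stated time of 72 h (on this read-out higher numbers stand for weaker inhibition and lower numbers for stronger inhibition), compound 2 gives 10300 nM, and compound 1, which carries the change ((methylsulfanyl)methyl in place of hydrogen on a saturated chain carbon, two bonds along the chain from an amine nitrogen and a carbonyl carbon), gives 19400 nM, so that a 1.9-fold higher number from compound 2 to compound 1 (0.27 log units; within the scatter). Compound 3 gives 20100 nM; how its core differs from that of compound 2 is not broken down here. Compound 4 `CSCC[C@H](NC1=CC(=O)C=C(C(C)(C)C)C1=O)C(=O)O` carries the same kind of change on the core of compound 3, namely ((methylsulfanyl)methyl in place of hydrogen on a saturated chain carbon, two bonds along the chain from an amine nitrogen and a carbonyl carbon). Resting on the step seen from compound 2 to compound 1, the expected step is a 1.4-fold higher number from compound 3 to compound 4 (0.14 log units; within the scatter), a small move that stays within the scatter. Compound 4 is therefore estimated at 28000 nM in this assay.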

Compound 4, half-maximal inhibitory concentration: 34800 nM
For compound 4 the middle estimate is 1.2-fold (0.09 log units) below the measured one, and the stated range covers the measured number.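

In this assay, the (methylsulfanyl)methyl group on the smaller core gives a 1.7-fold higher number from compound 3 to compound 4 (0.24 log units; within the scatter). Set beside the earlier step, the change reads alike on the two cores: the same change on two cores in this assay, a 1.9-fold higher number (0.27 log units; within the scatter) from compound 2 to compound 1 and a 1.7-fold higher number (0.24 log units; within the scatter) from compound 3 to compound 4, 1.1-fold (0.04 log units) apart, within the scatter of two such steps. Both steps lie within the scatter, so the change carries over from one core to the other without a step that stands out, but this does not show that it really shifts cytotoxicity, and two cores give no rule for others.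

The compounds shown hold only methyl and 2-(methylsulfanyl)ethyl at this chain carbon, so a longer chain without sulfur, or an amine on the chain, remains open. Also open, from the compounds shown here alone, is how either core would read with an ester in place of the carboxylic acid.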